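A few compounds are considered here, and "the series" means these few. Any claim that something is new, unique, unknown or untested is made for them only; others in the source may bear on it.

Three compounds in this series have a measured value in a functional assay on MCF7 cells (Homo sapiens) for antiproliferative activity, read by MTT assay, with a stated time of 48 h; on this read-out lower numbers stand for stronger inhibition and higher numbers for weaker inhibition. Compound 1 `COc1ccc(C(=O)c2ccc(OC)c3c2OC(C)(C)C=C3)c(NC(=O)CN)c1` gives 410 nM in this assay. Compound 3 `CNCC(=O)Nc1cc(OC)ccc1C(=O)c1ccc(OC)c2c1OC(C)(C)C=C2` differs from compound 1 by methyl in place of hydrogen on an amine nitrogen. In this assay compound 3 gives 820 nM, so that the step reads a 2.0-fold higher number from compound 1 to compound 3 (0.30 log units; within the scatter). Compound 2 `COc1ccc(C(=O)c2ccc3c(c2)C=CC(C)(C)O3)c(NC(=O)CN)c1` rests on a core that differs from that of compound 1; the difference between the two cores is not broken down here. In this assay compound 2 gives 680 nM, a number within the scatter of those of compound 1 and compound 3. Compound 4 `CNCC(=O)Nc1cc(OC)ccc1C(=O)c1ccc2c(c1)C=CC(C)(C)O2` has not yet been measured. It differs from compound 2 by methyl in place of hydrogen on an amine nitrogen, the same change that leads from compound 1 to compound 3, a change that appears twice among these compounds. Because the step of a 2.0-fold higher number from compound 1 to compound 3 (0.30 log units; within the scatter) stayed within the scatter, a step of similar size is expected here, a 1.9-fold higher number from compound 2 to compound 4 (0.28 log units; within the scatter). Compound 4 is therefore estimated to give 1300 nM in this assay, with a range expected from 550 nM to 3100 nM.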

Compound 4, half-maximal inhibitory concentration: 1210 nM
For compound 4 the middle estimate is 1.1-fold (0.03 log units) above the measured one, within the range that was stated.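

In this assay the new step reads a 1.8-fold higher number from compound 2 to compound 4 (0.25 log units; within the scatter), and like the earlier step on the core of compound 1 it stays within the scatter. Methyl in place of hydrogen on the amine nitrogen thus carries from one core to the other with no difference between the two steps: the same change on two cores in this assay, a 2.0-fold higher number (0.30 log units; within the scatter) from compound 1 to compound 3 and a 1.8-fold higher number (0.25 log units; within the scatter) from compound 2 to compound 4, 1.1-fold (0.05 log units) apart, within the scatter of two such steps

Each step lies within the scatter on its own, however, so these two pairs do not establish that the methyl shifts the number at all, and two cores say nothing about any other core or any other read-out. The compounds shown leave open what a larger group on this amine nitrogen would do, such as ethyl or a second methyl, and whether a longer chain carrying the amine would behave in the same way on both cores. They also leave open how a hydroxyl or a carboxylic acid in place of the amine would read in this assay.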